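The source may report more compounds than this note shows. Statements on the series, on what has been measured and on what is new or still open speak of the compounds shown alone.

Working notes on the series. The shared core is that of compound 1, `Nc1scc(CN2CCN(c3cc(Cl)cc(Cl)c3)CC2)c1C(=O)c1ccc(Cl)cc1`, varied only on the amine nitrogen in a ring. In a functional assay on CHO cells with adenosine receptor A1 (Homo sapiens) as the target, read by cAMP accumulation and immunoassay, with a stated time of 6 min, tested at 0.01 uM (on this read-out higher numbers stand for a weaker effect at the one concentration tested and lower numbers for a stronger effect), compound 1 gives -1%. Compound 2, `Nc1scc(CN2CCN(c3ccc(F)cc3Cl)CC2)c1C(=O)c1ccc(Cl)cc1`, gives 6.1% in this assay, and compound 3, `Nc1scc(CN2CCN(c3cccnc3)CC2)c1C(=O)c1ccc(Cl)cc1`, gives 3.2%. Compound 2 holds the highest of the three numbers, but the gaps are small: a number 2.9 percentage points lower from compound 2 to compound 3 (within the scatter), and a number 7.1 percentage points higher from compound 1 to compound 2 (within the scatter), neither beyond the scatter.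

Compound 4, `Nc1scc(CN2CCN(CCCc3ccc(Cl)cc3)CC2)c1C(=O)c1ccc(Cl)cc1`, differs from compound 2 by 3-(4-chlorophenyl)propyl in place of 2-chloro-4-fluorophenyl on an amine nitrogen in a ring. Within the data shown here, the steps that bear on this position, a number 7.1 percentage points higher from compound 1 to compound 2 (within the scatter), a number 4.2 percentage points higher from compound 1 to compound 3 (within the scatter) and a number 2.9 percentage points lower from compound 2 to compound 3 (within the scatter), all stayed inside the scatter, so no step beyond the scatter is expected in this assay in either direction. Compound 4 is therefore estimated at 3%, range -8% to 14%. The expected step is a number 3.1 percentage points lower from compound 2 to compound 4 (within the scatter).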

Compound 4, a percentage reported as activity, at one concentration (the size of the read-out at that concentration, not a potency): 0%
Estimate against measurement, compound 4: 3 percentage points above; the measured number falls inside the stated range.
By their numbers in this assay, from the lowest: compounds 1, 4, 3 and 2 (each within the scatter of the next).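

In this assay, 3-(4-chlorophenyl)propyl on the amine nitrogen in a ring brings a carbon chain to a position that otherwise carries its aromatic ring directly, yet every new step stays within the scatter: a number 6.1 percentage points lower from compound 2 to compound 4 (within the scatter), a number 3.2 percentage points lower from compound 3 to compound 4 (within the scatter) and a number 1 percentage points higher from compound 1 to compound 4 (within the scatter). This position therefore accepts the chain-borne ring and the directly attached rings with no separable difference on this read-out. No measurement here offers an explanation for this. Going by these compounds, whether a longer chain, or an amine or carboxylic acid at the chain end, would move the number beyond the scatter remains open. With one concentration, any potency differences among these compounds also remain open.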